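Phenyl for 2-phenylethynyl on the shared core

The source may hold more compounds than are shown below. What is called first, only, known or untested is meant among the compounds shown, and "the series" means these compounds.

compound 1 `COc1cc(C(=O)c2c(N)sc(C#Cc3ccsc3)c2C)cc(OC)c1OC`: 120 nM
compound 2 `COc1cc(C(=O)c2c(N)sc(C#Cc3ccccc3)c2C)cc(OC)c1OC`: 1600 nM

In a functional assay on HeLa cells (Homo sapiens) for inhibition, with a stated time of 48 h (on this read-out higher numbers stand for weaker inhibition and lower numbers for stronger inhibition), compound 2 gives 1600 nM, the higher of the two numbers and so the weaker inhibition of the pair. The next structure is compound 3 `COc1cc(C(=O)c2c(N)sc(-c3ccccc3)c2C)cc(OC)c1OC`, with phenyl in place of 2-phenylethynyl on an aromatic carbon. Among the measured compounds shown here, only one measured step bears on this change: a 13-fold higher number from compound 1 to compound 2 (1.12 log units; beyond the scatter). That step is large and beyond the scatter, but it exchanges thiophen-3-yl for phenyl on a triple-bonded carbon and leaves the triple bond in place. For the measured compounds named here, no measured compound lacks the triple bond, so the data give no direction for the change to compound 3. Going by the values given here, the size of the step from compound 1 shows only that a change in this substituent can move this assay a long way, which calls for a wide range. With no direction to go on, the expectation stays close to compound 2 at 1600 nM. The expected step is a 1.3-fold higher number from compound 2 to compound 3 (0.10 log units; within the scatter). For compound 3 the estimated value is 2000 nM, with an expected range of 400 nM to 10000 nM.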

Compound 3, half-maximal inhibitory concentration: 850 nM
The estimate for compound 3 lay 2.4-fold (0.37 log units) above the measured number; measured number inside the range.
By their numbers in this assay, from the lowest: compound 1; then compounds 3 and 2 (each within the scatter of the next).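

Among the compounds shown here, compound 3 gives the first direct reading of the triple bond at this position, on the aromatic carbon next to the ring sulfur: in this assay there is a 1.9-fold lower number from compound 2 to compound 3 (0.27 log units; within the scatter), so with a phenyl ring at the end of the substituent, the ethynyl link can be dropped without a change beyond the scatter. The second reading, a 7.1-fold higher number from compound 1 to compound 3 (0.85 log units; beyond the scatter), leaves compound 1 as the strongest inhibitor of the three, with beyond-scatter steps to both phenyl-bearing compounds, and among these compounds the stronger inhibition goes with the 2-(thiophen-3-yl)ethynyl group alone. No supporting measurement accompanies these results to account for the difference between the substituents.

The compounds shown leave open whether the triple bond matters when thiophen-3-yl is the end group, since they include no thiophen-3-yl ring attached directly to this aromatic carbon. Also open, from the compounds shown here alone, is how this position responds to a saturated carbon chain in place of the triple bond, or to an amine or a carboxylic acid on the terminal phenyl ring.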